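Fluoromethyl on the saturated ring of compound 2

The compounds below may be only part of what the source reports. "The series", "measured", "known", "first", "only" and "open" are said of these compounds alone.

In a physicochemical assay for lipophilicity, at pH 7.4 (a lower number here means a more polar compound, a higher number a more lipophilic compound), compound 1 (`CNC(=O)c1cc(C(=O)N[C@H]2[C@@H]3COC[C@@H]32)cc2c1OC[C@H]2c1cccc(OC)c1`) gives 3.2 and compound 2 (`CNC(=O)c1cc(C(=O)N[C@H]2[C@@H]3COC[C@@H]32)cc2c1OC[C@H]2c1ccccc1`) gives 3.3 and the two lie within the scatter of each other. Compound 3 (`CNC(=O)c1cc(C(=O)N[C@H]2[C@@H]3COC[C@@H]32)cc2c1O[C@H](CF)[C@H]2c1ccccc1`) carries fluoromethyl in place of hydrogen on a saturated ring carbon. Among the measured compounds shown here, the only measured step (a number 0.10 log units higher from compound 1 to compound 2 (within the scatter)) is hydrogen in place of methoxy on an aromatic carbon, so it bears only loosely on this change. In this assay a small step upward is expected, not clearly beyond the scatter. The expected change is a number 0.20 log units higher from compound 2 to compound 3 (within the scatter) at the middle of the estimate. Compound 3 is estimated at 3.5 (range 3.1 to 3.9).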

Compound 3, distribution coefficient: 3.6
Estimate against measurement, compound 3: 0.10 log units below; the range from low to high includes it.
By their numbers in this assay, from the lowest: compounds 1, 2 and 3 (each within the scatter of the next, the first and the last beyond it).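

Among the compounds shown here, at this saturated ring carbon, next to the ring oxygen and next to the ring atom that bears a phenyl group, fluoromethyl in place of hydrogen gives the first reading in this assay for a change on the saturated ring (a number 0.30 log units higher from compound 2 to compound 3 (within the scatter)). The earlier compounds shown here differed only on an aromatic carbon, and this step, too, stays within the scatter. Nothing measured here accounts for its size.

On these data alone, whether a hydroxymethyl, an aminomethyl or a longer chain on this carbon would read the same remains open. So does whether the fluoromethyl step would carry over to compound 1.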